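Working notes on the swap from compound 2 to compound 3

The source may report more compounds than this note shows. Statements on the series, on what has been measured and on what is new or still open speak of the compounds shown alone.

Measured compounds:
compound 1 `COc1cc(C(=O)N/N=C/c2ccccc2F)cc(OC)c1OC` — 76.5%
compound 2 `COc1cc(C2=NN(C(C)=O)C(c3ccccc3C(F)(F)F)O2)cc(OC)c1OC` — 34.8%

In a functional assay on BGC-823 cells (Homo sapiens) for antiproliferative activity, read by MTT assay, tested at 5 uM (on this read-out lower numbers stand for a weaker effect and higher numbers for a stronger effect at the one concentration tested), compound 1 gives 76.5%. In this assay compound 2 gives 34.8%. Within the data shown here, compound 2 stands lowest of the two numbers; its only neighbour is compound 1, whose value lies higher by a margin beyond the scatter. The two measured compounds differ in more than one place, so no single-change step can be read between them, and the gap says nothing about any one group.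

Compound 3 `COc1cc(C2=NN(C(C)=O)C(c3c(Cl)cccc3Cl)O2)cc(OC)c1OC` is still to be measured in this assay. Against compound 2 the change is 2,6-dichlorophenyl in place of 2-(trifluoromethyl)phenyl on a saturated ring carbon. Nothing in the measured pair shows what this kind of exchange does, so its direction is not fixed by the data; both groups are substituted phenyl rings of similar size. The expected step is a number 5.2 percentage points higher from compound 2 to compound 3 (within the scatter), small and quite possibly not beyond the scatter. Compound 3 is accordingly estimated at 40%, with a range from 20% to 65%.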

Compound 3, a percentage reported as inhibition, at one concentration (the size of the read-out at that concentration, not a potency): 15.9%
Estimate against measurement, compound 3: 24.1 percentage points above, and the stated range ends above it.
By their numbers in this assay, from the lowest: compound 3; then compound 2; then compound 1.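

In this assay, among these compounds, placing 2,6-dichlorophenyl in place of 2-(trifluoromethyl)phenyl on the saturated ring carbon gives a number 18.9 percentage points lower from compound 2 to compound 3 (beyond the scatter) and is the first single-change step available, so this position is not indifferent to which substituted phenyl ring it carries. Both groups have one six-membered aromatic ring of carbon only, with no hydrogen-bond donors, no hydrogen-bond acceptors and no net charge, so these shared features do not by themselves fix the read-out at this carbon. No measurement at hand accounts for the size or direction of this step.

Among the compounds shown here, the single exchange removes the trifluoromethyl group and brings in two chlorines at once, so it remains open which part of the change goes with the lower number, and whether a phenyl ring bearing one chlorine, an amine or a carboxylic acid at this carbon would sit nearer compound 2 or compound 3. Compound 1 differs from both in more than one place, so steps from it cannot be read.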